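This account rests on a few compounds, and the source may have more. Where it says the series, first, only, none or still open, it means among the compounds named here.

Measured so far:
compound 1 `COC(=O)[C@@]1(C)CCC=C2[C@@H]1CC[C@@H](C)[C@]2(C)Cc1c(C)[nH]c2c(Cl)cccc12`: 17000 nM
compound 2 `COC(=O)[C@@]1(C)CCC=C2[C@@H]1CC[C@@H](C)[C@]2(C)Cc1c(C)n(C(c2ccccc2)c2ccccc2)c2ccc(Cl)cc12`: > 100000 nM

In a functional assay on HeLa cells (Homo sapiens) for inhibition, read by sulforhodamine B assay, with a stated time of 48 h (a lower number here means a stronger inhibitor of growth, a higher number a weaker inhibitor of growth), compound 1 gives 17000 nM. Compound 2 gives only > 100000 nM, which is a limit of the assay and not a number. That value sits at the limit of > 100000 nM in this assay, at which 1 of the 2 values shown sits. Among the measured compounds shown here, compound 2 thus stands at the weak end of what has been measured, and no single-place step leads to it. Compound 3 `Cc1c(C[C@]2(C)C3=CCC[C@](C)(C(=O)O)[C@H]3CC[C@H]2C)c2cc(Cl)ccc2n1C(c1ccccc1)c1ccccc1` differs from compound 2 by hydrogen in place of methyl on an oxygen next to a carbonyl group. For the measured compounds named here, no measured step of this kind exists, so no size or direction beyond the scatter is claimed. For compound 3 the expected step is a number no higher from compound 2 to compound 3 (the limit leaves the size open). Compound 3 is estimated at 100000 nM, range 30000 nM to 300000 nM, with a limit again likely.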

Compound 3, concentration for 50% growth inhibition: 5500 nM
For compound 3 the middle estimate is 18-fold (1.26 log units) above the measured one; measured number below the stated range.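

In this assay, among the compounds shown here, replacing methoxycarbonyl with carboxy gives an at least 18-fold lower number from compound 2 to compound 3 (1.25 log units; beyond the scatter), the first measured evidence that the group at this place affects the read-out. Compound 2 gives > 100000 nM, which is a limit of the assay and not a number. The full size of the step therefore stays unknown: the limit of > 100000 nM in this assay, at which 1 of the 3 values shown sits.

The compounds shown leave open whether a primary amide or an ethyl ester at this place would read like compound 3 or like compound 2.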